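Cyanoguanidine aryl swap in a chromanol series

The source may hold more compounds than are shown below. What is called first, only, known or untested is meant among the compounds shown, and "the series" means these compounds.

Compound 1 `CC1(C)Oc2ccc(C#N)cc2[C@@H](NC(=O)Nc2cccnc2)[C@@H]1O`: 500 nM
Compound 2 `CC1(C)Oc2ccc(C#N)cc2[C@@H](N2CCN(c3ccccc3)C2=O)[C@@H]1O`: 23700 nM
Compound 3 `CC(=O)c1cccc(N/C(=N/[C@@H]2c3cc(C#N)ccc3OC(C)(C)[C@H]2O)NC#N)c1`: 8400 nM

Three compounds sharing one core were tested in a functional assay (aorta) with Rattus norvegicus as the target; a lower number here means a stronger inhibitor, a higher number a weaker inhibitor. Compound 1 `CC1(C)Oc2ccc(C#N)cc2[C@@H](NC(=O)Nc2cccnc2)[C@@H]1O` gives 500 nM in this assay, compound 2 `CC1(C)Oc2ccc(C#N)cc2[C@@H](N2CCN(c3ccccc3)C2=O)[C@@H]1O` gives 23700 nM, and compound 3 `CC(=O)c1cccc(N/C(=N/[C@@H]2c3cc(C#N)ccc3OC(C)(C)[C@H]2O)NC#N)c1` gives 8400 nM. On these numbers compound 3 stands second highest of the three; its nearest neighbour is compound 2, whose number is higher by an amount beyond the usual scatter, and its furthest is compound 1, whose number is lower by an amount well beyond the scatter.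

Compound 4 `CC1(C)Oc2ccc(C#N)cc2[C@@H](/N=C(\NC#N)Nc2ccc(Cl)c(Cl)c2)[C@@H]1O` has not yet been measured. It differs from compound 3 in one place: 3,4-dichlorophenyl in place of 3-acetylphenyl on an amine nitrogen. The change keeps the amine nitrogen and its carbon with a double bond to nitrogen and exchanges only the aryl group on it.

Among the measured compounds shown here, no measured pair shows the effect of this exchange. The account therefore expects for compound 4 a moderate step in this assay, with the number somewhat lower than that of compound 3, amounting to a 2.1-fold lower number from compound 3 to compound 4 (0.32 log units; beyond the scatter). Compound 4 is estimated at 4000 nM, in a range from 800 nM to 20000 nM.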

Compound 4, half-maximal inhibitory concentration: 4600 nM
Compound 4: middle estimate off by 1.2-fold (0.06 log units), on the low side, within the range that was stated.
By their numbers in this assay, from the lowest: compound 1; then compounds 4 and 3 (each within the scatter of the next); then compound 2.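

In this assay, among the compounds shown here, the exchange of 3-acetylphenyl for 3,4-dichlorophenyl on an amine nitrogen gives a 1.8-fold lower number from compound 3 to compound 4 (0.26 log units; within the scatter), the first reading of this position in the cyanoguanidine pair. The two aryl groups therefore cannot be told apart in this assay, even though one brings a carbonyl and the other two chlorines. This holds for this single pair only, and nothing measured here offers an explanation for the result.

On these data alone, whether a single chlorine, a methoxy group or a carboxylic acid on the phenyl ring would give a step beyond the scatter remains open. Neither compound 3 nor compound 4 differs in one place from compound 2 or from compound 1 at 500 nM, so the gap to that value cannot be assigned to any single part of the structure.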